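Changing the aromatic ring on a shared core

A few compounds are considered here, and "the series" means these few. Any claim that something is new, unique, unknown or untested is made for them only; others in the source may bear on it.

Of the compounds shown here, two have so far been measured in a functional assay on HOS cells (Homo sapiens) for antiproliferative activity, with a stated time of 72 h; on this read-out lower numbers stand for stronger inhibition and higher numbers for weaker inhibition. Compound 1 is `OC[C@H]1O[C@@H](n2cnc3c(NCc4ccccc4Br)ncnc32)[C@H](O)[C@@H]1O`. In this assay compound 1 gives > 166000 nM, which is a limit of the assay rather than a measured number. Compound 2 is `OC[C@H]1O[C@@H](n2cnc3c(NCc4ccc(F)c(Cl)c4)ncnc32)[C@H](O)[C@@H]1O`. In this assay compound 2 gives > 166000 nM, again a limit of the assay and not a number. The step that the two limits leave unreadable from compound 1 to compound 2 therefore cannot be read in size, as shown by the limit of > 166000 nM in this assay, at which 2 of the 2 values shown sit. Among the measured compounds shown here, compound 2 thus stands at that limit, and the one further value shown sits there too.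

Compound 3, not yet measured, is `OC[C@H]1O[C@@H](n2cnc3c(NCc4ccc(C(F)(F)F)cc4)ncnc32)[C@H](O)[C@@H]1O`. It differs from compound 2 by 4-(trifluoromethyl)phenyl in place of 3-chloro-4-fluorophenyl on a saturated chain carbon bound to a nitrogen on an aromatic ring. For the measured compounds named here, the only measured step, from compound 1 to compound 2, changed the group at the same place and gave no readable size, so no step beyond the scatter can be expected in this assay from the change at hand. Compound 3 is therefore expected to remain at the limit as well, with an estimated step that the limit leaves unreadable from compound 2 to compound 3. The estimate for compound 3 is 200000 nM, within a range from 100000 nM to 500000 nM.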

Compound 3, half-maximal inhibitory concentration: > 166000 nM
Compound 3: a limit, no number (the forecaster's own chance of this, stated with the estimate: 80%); the middle value is on the limit's open side.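

Compound 3, like compound 1 and compound 2, gives only a limit in this assay and not a number, so the size of the steps among these three compounds cannot be read: the limit of > 166000 nM in this assay, at which 3 of the 3 values shown sit.

The compounds shown leave open whether any change of the aromatic ring on the shared core would give a measurable number in this read-out.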